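The source may hold more compounds than are shown below. What is called first, only, known or untested is meant among the compounds shown, and "the series" means these compounds.

Series notes. Compound 1 `CN(/N=N/c1nc[nH]c1C(N)=O)c1cccs1` carries the shared core with a thiophen-2-yl group. In a functional assay on L1210 cells (Mus musculus) for antiproliferative activity (on this read-out higher numbers stand for higher potency (the scale is a negative logarithm) and lower numbers for lower potency), compound 1 gives 3.87, the highest of the three numbers recorded. Compound 3 `CC(C)Cc1nc(/N=N/N(C)C)c(C(N)=O)[nH]1`, the nearest of the others in this assay, gives 3.53, a gap from compound 1 that lies beyond the scatter. Compound 2 `CCCCN(C)/N=N/c1n[nH]cc1C(=O)OCC`, the furthest, gives 3.16 in this assay, also beyond the scatter from compound 1. Going by the values given here, no two of these three differ in only one place, so no single step between measured compounds can be read off.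

Compound 4 `CC(C)CN(C)/N=N/c1nc[nH]c1C(N)=O` has not been measured. It is drawn from compound 1 by a single change: isobutyl in place of thiophen-2-yl on an amine nitrogen. Among the compounds with values here, no measured pair shows this exchange, so its direction can only be judged loosely from compound 2, which on a different core comes with 3.16, and from compound 3, which comes with 3.53. Both sit under compound 1, and a downward step of moderate size, beyond the scatter, is expected rather than none. The step expected in this assay is a number 0.37 log units lower from compound 1 to compound 4 (beyond the scatter). Compound 4 is expected to give 3.5, within a range from 2.9 to 4.1.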

Compound 4, logarithm of the reciprocal of the active concentration, log(1/C): 3.51
Compound 4: middle estimate off by 0.01 log units, on the low side; the range from low to high includes it.
By their numbers in this assay, from the lowest: compound 2; then compounds 4 and 3 (each within the scatter of the next); then compound 1.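

On the amine nitrogen of the shared core, the exchange of thiophen-2-yl for isobutyl can now be read directly in this assay: the step is a number 0.36 log units lower from compound 1 to compound 4 (beyond the scatter). This is the first pair in the series that differs in one place, so this position is shown to affect the read-out with the rest of the structure held constant, something the earlier compounds, which differ in more than one place, could not show. The aromatic ring is not needed for activity to be recorded at this position, since compound 4, with an open isobutyl chain carrying no ring and no hydrogen-bond acceptor, still gives 3.51, although thiophen-2-yl remains the better of the two groups here. Nothing measured here accounts for the size or direction of this step.

The exchange alters ring, sulfur and chain shape together, so phenyl, furan-2-yl or a straight butyl chain on this nitrogen would be needed to tell these apart. As far as these compounds go, whether the same exchange gives a similar step on a core carrying an ethyl ester instead of the amide also remains open.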